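The source may report more compounds than this note shows. Statements on the series, on what has been measured and on what is new or still open speak of the compounds shown alone.

Measured in a functional assay on CCRF-CEM cells (Homo sapiens) for antiproliferative activity, read by cell counting, with a stated time of 96 h; on this read-out lower numbers stand for stronger inhibition and higher numbers for weaker inhibition:
- compound 1 `COc1ccc(Oc2ccccc2NC(C)=C2C(=O)CC(c3ccccc3)CC2=O)cc1OC`: 160 nM
- compound 2 `COc1cc(Oc2ccccc2NC(C)=C2C(=O)CC(c3ccccc3)CC2=O)ccc1N`: 12 nM
- compound 3 `CCOc1ccccc1NC(C)=C1C(=O)CC(c2ccccc2)CC1=O`: 190 nM

Among these three, compound 1 is not the extreme case on one side. Its nearest neighbour cannot be told apart from it: a 1.2-fold higher number from compound 1 to compound 3 (0.07 log units; within the scatter). Its furthest neighbour is clearly separated: a 13-fold lower number from compound 1 to compound 2 (1.12 log units; beyond the scatter).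

The next compound is compound 4 `COc1cccc(Oc2ccccc2NC(C)=C2C(=O)CC(c3ccccc3)CC2=O)c1`, which has hydrogen in place of methoxy on an aromatic carbon, ortho to a methoxy group and para to a large group: hydrogen in place of methoxy on an aromatic carbon. Put another way, 3,4-dimethoxyphenyl becomes 3-methoxyphenyl.

Among the compounds with values here, two measured steps bear on this change. The large step to compound 2 swaps the same methoxy for amino, so this place can matter. However, hydrogen is not amino, and no measured compound has hydrogen there. The step of a 16-fold higher number from compound 2 to compound 3 (1.20 log units; beyond the scatter) is also large, whereas removing the whole 3,4-dimethoxyphenyl group in favour of ethyl left compound 3 at 190 nM, within the scatter of compound 1. This suggests that the methoxy-bearing ring adds little here, so a small change is the likelier outcome, with no firm direction.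

The expected change is a 1.2-fold lower number from compound 1 to compound 4 (0.09 log units; within the scatter). In this assay, the estimate for compound 4 is 130 nM, with an expected range from 40 nM to 400 nM.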

Compound 4, half-maximal inhibitory concentration: 41 nM
Estimate against measurement, compound 4: 3.2-fold (0.50 log units) above, and the stated range covers the measured number.
By their numbers in this assay, from the lowest: compound 2; then compound 4; then compounds 1 and 3 (each within the scatter of the next).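

In this assay, replacing this methoxy with hydrogen is not a neutral change (a 3.9-fold lower number from compound 1 to compound 4 (0.59 log units; beyond the scatter)), so this place on the ring matters even when no new group enters. Amino keeps the lowest number (a 3.4-fold higher number from compound 2 to compound 4 (0.53 log units; beyond the scatter)), which puts the three groups seen at this aromatic carbon in a clear order: amino, then hydrogen, then methoxy. Compound 1 and compound 3 had seemed to say that an aromatic ring on this oxygen adds little over ethyl, but that holds only for 3,4-dimethoxyphenyl, since 3-methoxyphenyl does better than ethyl (a 4.6-fold lower number from compound 3 to compound 4 (0.67 log units; beyond the scatter)).

Still open, as far as these compounds go, is where a hydroxyl group or a fluorine atom at this same carbon would fall in that order, and whether amino would keep its lead if the remaining methoxy group were gone. Nothing available here explains why the three groups rank as they do.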